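The compounds below may be only part of what the source reports. "The series", "measured", "known", "first", "only" and "open" are said of these compounds alone.

Measured compounds in the series:
- compound 1, `COc1ccc(C(=O)/C=C/c2cc(-c3cc(OC)c(OC)c(OC)c3)n3nc(-c4ccccc4)cc3n2)cc1`, 79800 nM
- compound 2, `COc1ccc(-c2cc(/C=C/C(=O)c3ccc(C)c(C)c3)nc3cc(-c4ccccc4)nn23)cc1OC`, 46200 nM

Both numbers come from an ADME assay on HEK293 cells (Homo sapiens) for antiproliferative activity, read by MTT assay, with a stated time of 24 h; a lower number here means a stronger inhibitor, a higher number a weaker inhibitor. Compound 2 gives the lower of the two numbers, with compound 1 the nearest at a gap that sits within the usual scatter, so no order between compound 1 and compound 2 can be claimed on these data.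

The next step goes from compound 2 to compound 3, `COc1cc(-c2cc(/C=C/C(=O)c3ccc(C)c(C)c3)nc3cc(-c4ccccc4)nn23)cc(OC)c1OC`. The change is methoxy in place of hydrogen on an aromatic carbon. For the measured compounds named here, no step between two measured compounds isolates this change, so there is no measured precedent to lean on; the shared core and the rest of the molecule are unchanged.

Given how small the change is and how close compound 1 and compound 2 already sit, the expectation for compound 3 is a step of a 1.1-fold higher number from compound 2 to compound 3 (0.03 log units; within the scatter) in this assay, which is no movement beyond the scatter in either direction. The estimate for compound 3 is 50000 nM, with an expected range from 20000 nM to 120000 nM.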

Compound 3, half-maximal inhibitory concentration: 72500 nM
The estimate for compound 3 lay 1.5-fold (0.16 log units) below the measured number, and the stated range covers the measured number.
By their numbers in this assay, from the lowest: compounds 2, 3 and 1 (each within the scatter of the next).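

In this assay, going from 3,4-dimethoxyphenyl to 3,4,5-trimethoxyphenyl gives a 1.6-fold higher number from compound 2 to compound 3 (0.20 log units; within the scatter), so the added methoxy on this aromatic carbon produces no shift that can be told from the scatter. The group on the carbonyl carbon now has its first comparison at a single place: 3,4-dimethylphenyl in place of 4-methoxyphenyl gives a 1.1-fold lower number from compound 1 to compound 3 (0.04 log units; within the scatter), which also cannot be told from the scatter. No measurement at hand bears on the reason for these values.

Still open, as far as these compounds go, is whether any group on this aromatic carbon moves the number beyond the scatter, for example an amine or a carboxylic acid in place of the methoxy group. Also open, from the compounds shown here alone, is what a hydroxy group or a fluorine would do on the ring attached to the carbonyl carbon.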